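This account rests on a few compounds, and the source may have more. Where it says the series, first, only, none or still open, it means among the compounds named here.

Working notes, series around the shared core of compound 1, `Nc1scc(CN2CCN(c3cccc(Cl)c3Cl)CC2)c1C(=O)c1ccc(Cl)cc1`. In a functional assay on CHO cells with adenosine receptor A1 (Homo sapiens) as the target, read by cAMP accumulation and immunoassay, with a stated time of 6 min, tested at 1 uM (a higher number here means a weaker effect of the compound at the concentration tested, a lower number a stronger effect), compound 1 gives -57%, which places it second highest of the three numbers in hand: compound 2, `Nc1scc(CN2CCN(c3cccc(C(F)(F)F)c3)CC2)c1C(=O)c1ccc(Cl)cc1`, gives -72%, and compound 3, `Nc1scc(CN2CCN(c3ccc(Cl)c(C(F)(F)F)c3)CC2)c1C(=O)c1ccc(Cl)cc1`, gives -47%. Within the data shown here, the two swaps at the ring amine gave a number 15 percentage points lower from compound 1 to compound 2 (beyond the scatter) and a number 10 percentage points higher from compound 1 to compound 3 (within the scatter); the single chloro change gave a number 25 percentage points higher from compound 2 to compound 3 (beyond the scatter).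

Compound 4, `Nc1scc(CN2CCN(c3c(F)cc(F)cc3F)CC2)c1C(=O)c1ccc(Cl)cc1`, is the next member. Against compound 1 the change is 2,4,6-trifluorophenyl in place of 2,3-dichlorophenyl on an amine nitrogen in a ring. Among the measured compounds shown here, the steps that bear on this are the two aryl swaps from compound 1, since each replaces the whole 2,4,6-trifluorophenyl-type position with a differently substituted phenyl; both stayed modest, one within the scatter and one just beyond. A step of similar size is therefore expected for a number 2 percentage points higher from compound 1 to compound 4 (within the scatter), with no clear direction. Compound 4 is expected to give about -55% in this assay, within -78% to -32%.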

Compound 4, a percentage reported as activity, at one concentration (the size of the read-out at that concentration, not a potency): -56%
Compound 4: middle estimate off by 1 percentage points, on the high side, and the stated range covers the measured number.
By their numbers in this assay, from the lowest: compound 2; then compounds 1, 4 and 3 (each within the scatter of the next).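

In this assay the aryl group on the ring amine nitrogen need not carry chloro or trifluoromethyl: with only fluorine on the phenyl, the result is a number 1 percentage points higher from compound 1 to compound 4 (within the scatter) and a number 9 percentage points lower from compound 3 to compound 4 (within the scatter) in the same series. Among these compounds, the 2,4,6-trifluorophenyl group is also the first substitution pattern here with a group on each of three ring positions that matches 2,3-dichlorophenyl, yet a number 16 percentage points higher from compound 2 to compound 4 (beyond the scatter) keeps 3-(trifluoromethyl)phenyl in compound 2 as the one clearly separated member. No measured evidence accounts for any of these steps.

Open, going by these compounds, is whether an unsubstituted phenyl, or a phenyl bearing methoxy or nitrile, stays with compounds 1, 3 and 4 or with compound 2. On these data alone, all readings come from a single concentration, so potency across the series remains unknown.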